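Bromo to Trifluoromethyl on the Shared Core

A few compounds are considered here, and "the series" means these few. Any claim that something is new, unique, unknown or untested is made for them only; others in the source may bear on it.

Three compounds of one series were tested in a functional assay on PC-3 cells (Homo sapiens) for antiproliferative activity, read by MTT assay, with a stated time of 72 h; a lower number here means a stronger inhibitor, a higher number a weaker inhibitor. Compound 1 `CS(=O)(=O)c1ccc(-c2nc(SCCCOC(=O)/C=C/c3ccc(O)c(O)c3)nn2-c2ccc(Br)cc2)cc1` gave 12400 nM, compound 2 `CC(=O)Oc1ccc(/C=C/C(=O)NCCSc2nc(-c3ccc(S(C)(=O)=O)cc3)n(-c3ccc(F)cc3)n2)cc1OC(C)=O` gave 18000 nM, and compound 3 `COc1cc(/C=C/C(=O)OCCSc2nc(-c3ccc(S(C)(=O)=O)cc3)n(-c3ccc(Br)cc3)n2)ccc1OC(C)=O` gave 13100 nM. The number of compound 3 sits between the other two, and all three lie within the usual scatter of one another, so none of them can be called stronger or weaker in this assay. Compound 4 `COc1cc(/C=C/C(=O)OCCSc2nc(-c3ccc(S(C)(=O)=O)cc3)n(-c3ccc(C(F)(F)F)cc3)n2)ccc1OC(C)=O` differs from compound 3 in one place: trifluoromethyl in place of bromo on an aromatic carbon. Among the measured compounds shown here, no measured pair in this set isolates that change, so its effect in this assay is unknown. For the measured compounds named here, with the three known numbers so close together, the step is expected to be small, in no set direction, and probably within the scatter: a 1.0-fold lower number from compound 3 to compound 4 (0.00 log units; within the scatter). Compound 4 is therefore estimated at 13000 nM, with a range from 5000 nM to 35000 nM.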

Compound 4, half-maximal inhibitory concentration: 9810 nM
Estimate against measurement, compound 4: 1.3-fold (0.12 log units) above, within the range that was stated.
By their numbers in this assay, from the lowest: compounds 4, 1, 3 and 2 (each within the scatter of the next).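

In this assay, the change from 4-bromophenyl to 4-(trifluoromethyl)phenyl gives a 1.3-fold lower number from compound 3 to compound 4 (0.13 log units; within the scatter). Among the compounds shown here, this is the first pair in the set that differs in one place, and it shows that exchanging these two groups at this position leaves the number within the scatter. Nothing available bears on the reason for this result.

Going by these compounds, whether an amine or a carboxylic acid at this position would move the number beyond the scatter remains open. So does whether the same exchange gives a similar step with the amide link of compound 2.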